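Cyclopentyl in place of benzyl: expected clearance

The source may hold more compounds than are shown below. What is called first, only, known or untested is meant among the compounds shown, and "the series" means these compounds.

Compound 1 `COc1cnc(-c2ccccn2)nc1N(C)C1CCCC1` gives > 1000 mL/min/kg in an in vitro ADME assay on microsomes from liver (Rattus norvegicus) for metabolic stability, read by LC-MS, tested at 0.05 uM (on this read-out higher numbers stand for fast clearance and lower numbers for slow clearance), a limit of the assay.
Compound 2 `COc1cnc(-c2ccccn2)nc1C1CCCC1` gives > 1000 mL/min/kg in this assay, again a limit.
Compound 3 `COc1cnc(-c2ccccn2)nc1NCc1ccccc1` gives 387 mL/min/kg in this assay.

Compound 3 carries the only plain number shown; the other two values sit at the limit of > 1000 mL/min/kg in this assay, at which 2 of the 3 values shown sit. Compound 4 `COc1cnc(-c2ccccn2)nc1NC1CCCC1` differs from compound 3 by cyclopentyl in place of benzyl on a nitrogen on an aromatic ring. Among the compounds with values here, the single measured step, a step that the two limits leave unreadable from compound 1 to compound 2, does not touch this change and its size cannot be read. Compound 1, which also carries a cyclopentyl on that nitrogen, sits at the limit. Compound 4 is therefore expected to clear faster than compound 3, by about a 1.7-fold higher number from compound 3 to compound 4 (0.23 log units; within the scatter), giving an estimated 650 mL/min/kg (range 250 mL/min/kg to 1500 mL/min/kg), with a real chance that only a limit is reported.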

Compound 4, clearance: 202 mL/min/kg
Estimate against measurement, compound 4: 3.2-fold (0.51 log units) above; the measured number lies below the stated range.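

In this assay, cyclopentyl in place of benzyl on this nitrogen gives a 1.9-fold lower number from compound 3 to compound 4 (0.28 log units; within the scatter), so these two groups cannot be told apart here. The larger changes lie elsewhere: hydrogen in place of methyl on the same nitrogen gives an at least 4.9-fold lower number from compound 1 to compound 4 (0.69 log units; beyond the scatter), and cyclopentylamino in place of cyclopentyl on the aromatic carbon gives an at least 4.9-fold lower number from compound 2 to compound 4 (0.69 log units; beyond the scatter). Compound 1 and compound 2 both stand at a limit, so these two sizes are only minimums: the limit of > 1000 mL/min/kg in this assay, at which 2 of the 4 values shown sit. Going by these compounds, whether a longer chain or a ring carrying an amine on this nitrogen would give a clearly different number stays open.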